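Moving a methyl on the pyridine ring: expected solubility

A few compounds are considered here, and "the series" means these few. Any claim that something is new, unique, unknown or untested is made for them only; others in the source may bear on it.

Measured compounds:
compound 1 `Cn1c(COc2cccc(C(=O)O)c2)nc2ccc(Oc3cccc(Cl)n3)cc21` — 7.7 ug/mL
compound 2 `Cn1c(COc2cccc(C(=O)O)c2)nc2ccc(Oc3ccc(Cl)cn3)cc21` — 17 ug/mL
compound 3 `Cc1ccc(Oc2ccc3nc(COc4cccc(C(=O)O)c4)n(C)c3c2)nc1` — 31 ug/mL

In a physicochemical assay for solubility, read by HPLC, measured as thermodynamic solubility, with a stated time of 4 h, at pH 6.8 (on this read-out higher numbers stand for higher solubility and lower numbers for lower solubility), compound 3 gives the highest of the three numbers. Its nearest neighbour is compound 2, and that gap, a 1.8-fold higher number from compound 2 to compound 3 (0.26 log units; within the scatter), lies within the scatter. The gap to compound 1, a 4.0-fold higher number from compound 1 to compound 3 (0.60 log units; beyond the scatter), lies beyond it.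

Compound 4 `Cc1cccnc1Oc1ccc2nc(COc3cccc(C(=O)O)c3)n(C)c2c1` has not yet been measured in this assay. It differs from compound 3 by 3-methylpyridin-2-yl in place of 5-methylpyridin-2-yl on an oxygen on an aromatic ring; the same atoms are present, joined differently.

Among the compounds with values here, no measured step moves a methyl around the pyridine ring. The closest analogy is a 2.2-fold higher number from compound 1 to compound 2 (0.34 log units; beyond the scatter), where a chloro was moved to another carbon of the same ring and the number rose modestly. The step of a 1.8-fold higher number from compound 2 to compound 3 (0.26 log units; within the scatter) shows that swapping methyl for chloro on that ring stays within the scatter. Compound 4 is therefore expected to sit near compound 3, with a step of a 1.1-fold lower number from compound 3 to compound 4 (0.06 log units; within the scatter) that is not expected to exceed the scatter in either direction. The estimate for compound 4 in this assay is 27 ug/mL, with a range from 11 ug/mL to 65 ug/mL.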

Compound 4, solubility: 37 ug/mL
For compound 4 the middle estimate is 1.4-fold (0.14 log units) below the measured one; the range from low to high includes it.
By their numbers in this assay, from the lowest: compound 1; then compounds 2, 3 and 4 (each within the scatter of the next, the first and the last beyond it).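

In this assay, moving the methyl from 5-methylpyridin-2-yl to 3-methylpyridin-2-yl gives a step within the scatter (a 1.2-fold higher number from compound 3 to compound 4 (0.08 log units; within the scatter)), so this first methyl move on the ring does not go beyond the scatter, as the earlier chloro move did. The change also separates compound 4 from both chloropyridines, by steps beyond the scatter (a 2.2-fold higher number from compound 2 to compound 4 (0.34 log units; beyond the scatter); a 4.8-fold higher number from compound 1 to compound 4 (0.68 log units; beyond the scatter)), whereas compound 3 stood within the scatter of compound 2. No measurement offered here accounts for these numbers.

The compounds shown leave open whether the same tolerance holds for groups other than methyl and chloro on this ring, such as an amine or a methoxy. They also leave open whether replacing the pyridine with an unsubstituted phenyl ring would keep the number in this range.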